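A few compounds are considered here, and "the series" means these few. Any claim that something is new, unique, unknown or untested is made for them only; others in the source may bear on it.

The study concerns three compounds that share one core. Compound 1 is `COC(=O)c1ccc(NCc2cncn2Cc2ccccc2)cc1-c1ccccc1`. In a toxicity assay on NIH3T3 cells (Mus musculus) for cytotoxicity, read by resazurin assay (a higher number here means that more compound is needed for the effect, a lower number that less compound is needed), compound 1 gives only a limit, > 1000 nM, and not a number. Among the measured compounds shown here, compound 2 is `COC(=O)c1ccc(NCc2cncn2Cc2ccc(OC)cc2)cc1-c1ccccc1`; in this assay compound 2 stands at "not determined" (no result reported), so no single number exists for it, and the one further value shown for the series sits at the limit of > 1000 nM in this assay, at which 1 of the 2 values shown sits. Compound 3 is `COC(=O)c1ccc(NCc2cncn2Cc2ccc(Br)cc2)cc1-c1ccccc1`, and it has not yet been tested in this assay. It differs from compound 2 in one place: bromo in place of methoxy on an aromatic carbon. No step between two measured compounds is shown here, so the size of the change from compound 2 to compound 3 in this assay cannot be read from a measured pair; with the one shown value resting at the limit, the expectation is for no shift beyond the usual scatter, in either direction. For compound 3 in this assay the estimated value is 3000 nM, with an expected range from 800 nM to 20000 nM, and it is expected that the result may again come back as a limit rather than a number.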

Compound 3, half-maximal effective concentration: > 10000 nM
Compound 3: only a limit was reported; the forecaster's own chance of this, stated with the estimate: 75%; at least 3.3-fold (0.52 log units) between middle value and limit.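

Compound 1 and compound 3 both give only limits in this assay, and compound 2 has no number there, so no step can be read among these three compounds. The compounds shown leave open how far hydrogen, methoxy or bromo at that place on the aromatic ring shifts the concentration needed in this assay.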